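The compounds below may be only part of what the source reports. "The series", "measured", "known", "first", "only" and "open" are said of these compounds alone.

Measured so far:
compound 1 `CCN(CC)CCNC(=O)c1ccc(C(CC)(CC)c2ccc(OCC(=O)C(C)(C)C)c(C)c2)n1CC` — 91 nM
compound 2 `CC[C@@H](C)[C@H](NC(=O)c1ccc(C(CC)(CC)c2ccc(OCC(O)C(C)(C)C)c(C)c2)n1CC)C(=O)OC` — 26 nM
compound 3 `CCOC(=O)CN(C)C(=O)c1ccc(C(CC)(CC)c2ccc(OCC(O)C(C)(C)C)c(C)c2)n1CC` — 210 nM

All three share one core and are read in an assay on HL-60 cells for agonist activity at vitamin D3 receptor (Homo sapiens), read by microscopy, with a stated time of 96 h; a higher number here means that more compound is needed for the effect, a lower number that less compound is needed. Compound 3 stands at the highest number of the three: compound 1 sits at a lower number, and compound 2 sits at a lower number still. Among the measured compounds shown here, the one measured step that changes the amide, an 8.1-fold higher number from compound 2 to compound 3 (0.91 log units; beyond the scatter), shows that swapping the group on the carbonyl carbon can move the result by a modest but real amount.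

Compound 4 `CCN(CC)CCNC(=O)c1ccc(C(CC)(CC)c2ccc(OCC(O)C(C)(C)C)c(C)c2)n1CC` is not yet measured. It differs from compound 3 in one place: (2-(diethylamino)ethyl)amino in place of ((ethoxycarbonyl)methyl)(methyl)amino on a carbonyl carbon. For the measured compounds named here, the group that enters is the same one carried by compound 1, which in this assay gives 91 nM, though compound 1 and compound 4 are not the same molecule and no step between them has been measured. The step from compound 2 to compound 3 bears on the present change only in that it shows amide swaps matter here; it does not say in which direction this particular swap will go.

Taking compound 1 as the nearest guide, compound 4 is expected to give 60 nM, within a range of 20 nM to 200 nM. The expected step, a 3.5-fold lower number from compound 3 to compound 4 (0.54 log units; beyond the scatter), is estimated to be a lowering of the number beyond the scatter.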

Compound 4, half-maximal effective concentration: 110 nM
Compound 4: the middle estimate sits 1.8-fold (0.26 log units) below what was measured, and the stated range covers the measured number.
By their numbers in this assay, from the lowest: compound 2; then compounds 1, 4 and 3 (each within the scatter of the next, the first and the last beyond it).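

In this assay, putting (2-(diethylamino)ethyl)amino in place of ((ethoxycarbonyl)methyl)(methyl)amino on the carbonyl carbon gives a 1.9-fold lower number from compound 3 to compound 4 (0.28 log units; within the scatter) and so leaves these two quite different amide groups indistinguishable, even though only the entering group carries a hydrogen-bond donor. The amide position is still not indifferent, since 2-(diethylamino)ethyl in place of 1-(methoxycarbonyl)-2-methylbutyl on the amide-type nitrogen gives a 4.2-fold higher number from compound 2 to compound 4 (0.63 log units; beyond the scatter) and this is a real change, so among these amides the group of compound 2 is the one that stands apart. At the other end of the molecule, 1-hydroxy-2,2-dimethylpropyl in place of (tert-butyl)carbonyl gives a 1.2-fold higher number from compound 1 to compound 4 (0.08 log units; within the scatter) and shows that, with this amide, the alcohol and the ketone read alike.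

From the compounds shown here alone, it remains open whether a carboxylic acid in place of the methoxycarbonyl group of compound 2, or a piperidine in place of the diethylamino group of compound 4, would hold or shift the number. Nothing measured here accounts for why one amide swap registers and the other does not.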